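Cytotoxicity notes on the ring-amide substituent series

A few compounds are considered here, and "the series" means these few. Any claim that something is new, unique, unknown or untested is made for them only; others in the source may bear on it.

Compounds 1, 2 and 3 share one core and differ in the group on a saturated chain carbon bound to an amide-type nitrogen in a ring. Compound 1 `COc1ccc2[nH]c(C(=O)N3CC(=O)N(Cc4ccoc4)[C@@H](Cc4ccccc4)C3)cc2c1` carries furan-3-yl there; in an ADME assay on Vero cells (Chlorocebus sabaeus) for cytotoxicity, with a stated time of 7 days (on this read-out higher numbers stand for lower toxicity in this test and lower numbers for higher toxicity in this test), compound 1 gives only a limit of the assay, > 10000 nM. Compound 2 `COc1ccc2[nH]c(C(=O)N3CC(=O)N(Cc4cccc(OC)n4)[C@@H](Cc4ccccc4)C3)cc2c1` carries 6-methoxypyridin-2-yl, and in this assay compound 2 likewise gives a limit, > 30000 nM. For the measured compounds named here, compound 3 `COc1ccc2[nH]c(C(=O)N3CC(=O)N(Cc4ccc[nH]4)[C@@H](Cc4ccccc4)C3)cc2c1` carries 1H-pyrrol-2-yl, and in this assay compound 3 gives 15200 nM, the only number in the set. The other two values are limits. The steps a step that the two limits leave unreadable from compound 1 to compound 2 and a step that the limit leaves unreadable from compound 1 to compound 3 cannot be read, and an at least 1.9-fold lower number from compound 2 to compound 3 (0.29 log units; that floor lies within the scatter) is the only readable one. Compound 4 `COc1ccc2[nH]c(C(=O)N3CC(=O)N(c4ccccc4)[C@@H](Cc4ccccc4)C3)cc2c1` differs from compound 3 as follows: phenyl in place of (1H-pyrrol-2-yl)methyl on an amide-type nitrogen in a ring. Going by the values given here, none of the measured steps concerns a group attached directly to the ring nitrogen; the readable step of an at least 1.9-fold lower number from compound 2 to compound 3 (0.29 log units; that floor lies within the scatter) shows only that exchanging one aryl for another on the chain carbon moved the read-out little. The expected step is therefore a 1.0-fold lower number from compound 3 to compound 4 (0.01 log units; within the scatter), none beyond the scatter. For compound 4 the value in this assay is estimated at 15000 nM, between 5000 nM and 40000 nM.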

Compound 4, half-maximal cytotoxic concentration: > 30000 nM
Compound 4 gave a limit, no number (the forecaster's own chance of this, stated with the estimate: 30%); at least 2.0-fold (0.30 log units) between middle value and limit.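

In this assay, setting phenyl on the amide-type nitrogen in a ring, in place of (1H-pyrrol-2-yl)methyl, gives an at least 1.9-fold higher number from compound 3 to compound 4 (0.29 log units; that floor lies within the scatter). Unlike the earlier steps, which exchanged only the aryl group on the saturated chain carbon, this one also removes that chain carbon, and the read-out still shows no toxicity gain beyond the scatter. Compound 4 gives only a limit, the steps to it from compound 1 and compound 2 cannot be read, and that limit is shared with one other compound: the limit of > 30000 nM in this assay, at which 2 of the 4 values shown sit.

From the compounds shown here alone, how far the true value of compound 4 lies past its limit stays open, so the full size of this change is unknown. Also open, going by these compounds, is how a phenyl bearing a carboxylic acid, or a longer chain such as 2-phenylethyl, on that nitrogen would read in this assay.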